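The compounds below may be only part of what the source reports. "The series", "measured", "known", "first", "only" and "open" are said of these compounds alone.

In an assay on CHO cells for displacement of a labelled ligand from 5-hydroxytryptamine receptor 1D (Homo sapiens) (on this read-out lower numbers stand for stronger inhibition and higher numbers for weaker inhibition), compound 1 `c1ccc(CNCC2CCN(CCCc3c[nH]c4ccc(-n5cnnc5)cc34)CC2)cc1` gives 1.6 nM and compound 2 `CN(Cc1ccccc1)CC1CCN(CCCc2c[nH]c3ccc(-n4cnnc4)cc23)CC1` gives 0.9 nM, the lowest of the two numbers, separated only by the step of a 1.8-fold lower number from compound 1 to compound 2 (0.25 log units; within the scatter). Compound 3 `c1ccc(NCC2CCN(CCCc3c[nH]c4ccc(-n5cnnc5)cc34)CC2)nc1` carries (pyridin-2-yl)amino in place of benzyl(methyl)amino on a saturated chain carbon bound to a saturated ring carbon. Among the measured compounds shown here, of the measured steps, only the one from compound 1 to compound 2 touches this change, and it covers just the methyl on the amine nitrogen; the exchange of the benzyl group for the pyridin-2-yl group has no measured counterpart. Compound 3 is therefore expected to show a modest rise in this assay, a step of a 5.6-fold higher number from compound 2 to compound 3 (0.74 log units; beyond the scatter). The estimate for compound 3 is 5 nM, between 1 nM and 25 nM.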

Compound 3, half-maximal inhibitory concentration: 1.7 nM
Compound 3: the middle estimate sits 2.9-fold (0.47 log units) above what was measured; measured number inside the range.
By their numbers in this assay, from the lowest: compounds 2, 1 and 3 (each within the scatter of the next).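

In this assay, pyridin-2-yl in place of benzyl on the amine nitrogen gives a 1.1-fold higher number from compound 1 to compound 3 (0.03 log units; within the scatter), and the full exchange of benzyl(methyl)amino for (pyridin-2-yl)amino gives a 1.9-fold higher number from compound 2 to compound 3 (0.28 log units; within the scatter). Among these three compounds, this position therefore accepts a six-membered aromatic ring with a hetero atom in place of the benzyl group, with both steps staying within the scatter. Going by these compounds, whether a phenyl or pyridin-3-yl group on the same amine nitrogen would also stay within the scatter remains open. Nothing available accounts for this result.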